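The compounds below may be only part of what the source reports. "The series", "measured", "known", "first", "only" and "open" are said of these compounds alone.

In a functional assay on MCF7 cells (Homo sapiens) for cytotoxicity, read by MTT assay, with a stated time of 68 h (a higher number here means a weaker inhibitor, a lower number a stronger inhibitor), compound 1 `O=C(/C=C/c1cccc(OCc2ccccc2)c1)c1ccc([N+](=O)[O-])cc1` gives 17500 nM, compound 2 `O=C(/C=C/c1cccc(OCc2ccccc2)c1)c1ccc(Br)cc1` gives 6500 nM and compound 3 `O=C(/C=C/c1cccc(OCc2ccccc2)c1)c1ccccc1Br` gives 1600 nM, which places compound 2 in the middle of the three. Compound 4 `O=C(/C=C/c1cccc(OCc2ccccc2)c1)c1ccc(Cl)c(Cl)c1Cl` keeps the core of compound 2 and changes one group: 2,3,4-trichlorophenyl in place of 4-bromophenyl on a carbonyl carbon. The closest guide is the modest 4.1-fold lower number from compound 2 to compound 3 (0.61 log units; beyond the scatter), seen with 2-bromophenyl in place of 4-bromophenyl, since 2-bromophenyl is the nearest measured match to 2,3,4-trichlorophenyl. For the measured compounds named here, the modest 2.7-fold lower number from compound 1 to compound 2 (0.43 log units; beyond the scatter) helps less, and no measured compound carries chlorine. A modest fall in this assay is therefore expected, and the estimated step is a 2.2-fold lower number from compound 2 to compound 4 (0.34 log units; beyond the scatter). Compound 4 is expected at about 3000 nM, with an estimated range of 1000 nM to 9000 nM.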

Compound 4, half-maximal inhibitory concentration: 2400 nM
For compound 4 the middle estimate is 1.3-fold (0.10 log units) above the measured one, within the range that was stated.
By their numbers in this assay, from the lowest: compounds 3 and 4 (each within the scatter of the next); then compound 2; then compound 1.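

In this assay the 2,3,4-trichlorophenyl group on the carbonyl carbon gives a 2.7-fold lower number from compound 2 to compound 4 (0.43 log units; beyond the scatter) and also a 7.3-fold lower number from compound 1 to compound 4 (0.86 log units; beyond the scatter) so a ring with three chlorines is tolerated at this place. Measured against 2-bromophenyl, the change gives a 1.5-fold higher number from compound 3 to compound 4 (0.18 log units; within the scatter) and the two rings cannot be told apart. Nothing available explains these differences. From the compounds shown here alone, it remains open how 2-chlorophenyl, with its single chlorine, would compare with 2-bromophenyl. An amine or a carboxylic acid on this ring is also untested among the compounds shown.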